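Amide aryl variation on a naphthyl thiazolidinedione series

A few compounds are considered here, and "the series" means these few. Any claim that something is new, unique, unknown or untested is made for them only; others in the source may bear on it.

compound 1 `CCOc1ccc2nc(NC(=O)COc3ccc4cc(/C=C5/SC(=O)NC5=O)ccc4c3)sc2c1`: 3600 nM
compound 2 `O=C(COc1ccc2cc(/C=C3/SC(=O)NC3=O)ccc2c1)Nc1ccc(F)cc1F`: 3900 nM
compound 3 `Cc1cc(Br)ccc1NC(=O)COc1ccc2cc(/C=C3/SC(=O)NC3=O)ccc2c1`: 550 nM

All three numbers come from an assay on isolated protein for inhibition of histone deacetylase 4 (Homo sapiens), with a stated time of 1 h; on this read-out higher numbers stand for weaker inhibition and lower numbers for stronger inhibition. Compound 3 holds the lowest of the three, with compound 1 and compound 2 both beyond the scatter above it. Among the compounds with values here, the one single-point step measured, a 7.1-fold lower number from compound 2 to compound 3 (0.85 log units; beyond the scatter), shows that exchanging the aryl group on the amide-type nitrogen can move the number well beyond the scatter. Compound 4 `Cc1cccc(NC(=O)COc2ccc3cc(/C=C4/SC(=O)NC4=O)ccc3c2)n1` differs from compound 3 as follows: 6-methylpyridin-2-yl in place of 4-bromo-2-methylphenyl on an amide-type nitrogen. Within the data shown here, no measured step puts a ring with a hetero atom at this position, so the direction is open. Compound 1 and compound 2, the other aryl variants, both sit beyond the scatter above compound 3. On that basis compound 4 is expected to move by a 3.6-fold higher number from compound 3 to compound 4 (0.56 log units; beyond the scatter). The estimate for compound 4 in this assay is 2000 nM, in the range 600 nM to 6000 nM.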

Compound 4, half-maximal inhibitory concentration: 1100 nM
For compound 4 the middle estimate is 1.8-fold (0.26 log units) above the measured one, and the stated range covers the measured number.
By their numbers in this assay, from the lowest: compounds 3 and 4 (each within the scatter of the next); then compounds 1 and 2 (each within the scatter of the next).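

In this assay, 6-methylpyridin-2-yl is the only ring with a hetero atom on the amide-type nitrogen among these compounds, and it gives a 2.0-fold higher number from compound 3 to compound 4 (0.30 log units; within the scatter), so a ring without bromine can stay level with compound 3. The same group gives a 3.5-fold lower number from compound 2 to compound 4 (0.55 log units; beyond the scatter), showing that a ring with a hetero atom can also separate from 2,4-difluorophenyl. Nothing available gives a reason for either step. Open, on these data alone, is whether a carboxylic acid on this ring, or a saturated ring such as piperidine in its place, would hold the number at this level.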